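Methoxy in Place of Methylsulfonyl on the Hydrazone Aryl Ring

This account rests on a few compounds, and the source may have more. Where it says the series, first, only, none or still open, it means among the compounds named here.

Three compounds have been measured in a functional assay on PC-3 cells (Homo sapiens) for antiproliferative activity, read by MTT assay; a lower number here means a stronger inhibitor, a higher number a weaker inhibitor:
Compound 1 `Cn1c(=O)c(=O)n(C2CCCC2)c2nc(N/N=C/c3ccccc3)ncc21` gives 48200 nM.
Compound 2 `Cn1c(=O)c(=O)n(C2CCCC2)c2nc(N/N=C/c3ccc(Cl)cc3)ncc21` gives 8420 nM.
Compound 3 `Cn1c(=O)c(=O)n(C2CCCC2)c2nc(N/N=C/c3ccc(S(C)(=O)=O)cc3)ncc21` gives 26600 nM.

Compound 3 holds the second highest of the three numbers; it lies within the usual scatter of compound 1, so the two cannot be ranked, whereas the step of a 3.2-fold higher number from compound 2 to compound 3 (0.50 log units; beyond the scatter) is beyond the scatter. Compound 4 `COc1ccc(/C=N/Nc2ncc3c(n2)n(C2CCCC2)c(=O)c(=O)n3C)cc1` differs from compound 3 by methoxy in place of methylsulfonyl on an aromatic carbon. Going by the values given here, no measured step involves methoxy. The steps of a 5.7-fold lower number from compound 1 to compound 2 (0.76 log units; beyond the scatter) and a 1.8-fold lower number from compound 1 to compound 3 (0.26 log units; within the scatter) show that a group on this aromatic carbon shifts the number only modestly, and nothing shows which way methoxy goes. A step close to nothing is therefore expected, a 1.3-fold lower number from compound 3 to compound 4 (0.12 log units; within the scatter), with a wide range. Compound 4 is expected to give 20000 nM, estimated between 6000 nM and 60000 nM.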

Compound 4, half-maximal inhibitory concentration: 26300 nM
Compound 4: the middle estimate sits 1.3-fold (0.12 log units) below what was measured, within the range that was stated.
By their numbers in this assay, from the lowest: compound 2; then compounds 4, 3 and 1 (each within the scatter of the next).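

In this assay, methoxy on this aromatic carbon reads like methylsulfonyl (a 1.0-fold lower number from compound 3 to compound 4 (0.00 log units; within the scatter)) and like plain hydrogen (a 1.8-fold lower number from compound 1 to compound 4 (0.26 log units; within the scatter)), so these three groups cannot be ranked here. Chloro alone stands apart from all three (a 3.1-fold higher number from compound 2 to compound 4 (0.49 log units; beyond the scatter)), a separation that earlier rested on only two groups. Nothing available explains why chloro differs.

From the compounds shown here alone, whether an amine or a carboxylic acid on this carbon would fall with chloro or with the other three remains open. So does whether chloro would stand apart on another carbon of this ring.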